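Carbonyl substituent variation on a shared core

This account rests on a few compounds, and the source may have more. Where it says the series, first, only, none or still open, it means among the compounds named here.

Measured so far in a functional assay on isolated protein for inhibition of Glucose-dependent insulinotropic receptor (Rattus norvegicus), read by HTRF and cAMP accumulation; a lower number here means that less compound is needed, a higher number that more compound is needed for the effect:
compound 1, `Cc1nc(S(C)(=O)=O)ccc1Oc1ncnc(OC2CCN(C(=O)OC3CCC3)CC2)c1F`, 167 nM
compound 2, `Cc1nc(S(C)(=O)=O)ccc1Oc1ncnc(OC2CCN(C(=O)OC(C)F)CC2)c1F`, 315 nM
compound 3, `CCC(F)(F)C(=O)N1CCC(Oc2ncnc(Oc3ccc(S(C)(=O)=O)nc3C)c2F)CC1`, 69.2 nM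

The three compounds share one core and differ only in the group on the carbonyl carbon that is bound to the amide-type nitrogen in a ring. Compound 3 stands lowest of the three numbers: the steps of a 2.4-fold lower number from compound 1 to compound 3 (0.38 log units; beyond the scatter) and a 4.6-fold lower number from compound 2 to compound 3 (0.66 log units; beyond the scatter) both lie beyond the scatter, while a 1.9-fold higher number from compound 1 to compound 2 (0.28 log units; within the scatter) does not.

Compound 4, `Cc1nc(S(C)(=O)=O)ccc1Oc1ncnc(OC2CCN(C(=O)c3noc(C(C)C)n3)CC2)c1F`, has not yet been measured in this assay. It differs from compound 3 as follows: 5-isopropyl-1,2,4-oxadiazol-3-yl in place of 1,1-difluoropropyl on a carbonyl carbon. Among the measured compounds shown here, the steps that bear on this position are a 2.4-fold lower number from compound 1 to compound 3 (0.38 log units; beyond the scatter) and a 4.6-fold lower number from compound 2 to compound 3 (0.66 log units; beyond the scatter), both modest in size. Neither of them introduces a ring or hydrogen-bond acceptors at this carbon, so they give no direction for the present change; they only show that this position tolerates modest swings. For compound 4 a step of a 1.7-fold higher number from compound 3 to compound 4 (0.24 log units; within the scatter) is therefore expected, a small loss that may lie within the scatter. The estimate for compound 4 is 120 nM, with a range from 40 nM to 400 nM.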

Compound 4, half-maximal effective concentration: 176 nM
Compound 4: the middle estimate sits 1.5-fold (0.17 log units) below what was measured; low and high end bracket the measured number.
By their numbers in this assay, from the lowest: compound 3; then compounds 1, 4 and 2 (each within the scatter of the next).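

In this assay, the carbonyl carbon bound to the amide-type nitrogen in a ring carries 5-isopropyl-1,2,4-oxadiazol-3-yl, a five-membered aromatic ring, with a 2.5-fold higher number from compound 3 to compound 4 (0.41 log units; beyond the scatter), so this change from 1,1-difluoropropyl gives a modest loss beyond the scatter. The same group cannot be separated from the two oxygen-linked groups, with a 1.1-fold higher number from compound 1 to compound 4 (0.02 log units; within the scatter) and a 1.8-fold lower number from compound 2 to compound 4 (0.25 log units; within the scatter) both within the scatter, so among these four compounds only compound 3 stands apart. No measurement at hand accounts for the step to compound 4.

Going by these compounds, whether that step follows the aromatic ring itself or the isopropyl on it remains open. A 5-methyl-1,2,4-oxadiazol-3-yl or a phenyl group on the same carbonyl carbon would separate the two, and a longer difluoroalkyl chain would show how far the 1,1-difluoropropyl result extends.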